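Working notes: heteroaryl amide swap, compound 3 to compound 4

This account rests on a few compounds, and the source may have more. Where it says the series, first, only, none or still open, it means among the compounds named here.

Measured so far:
compound 1 `O=C(NCc1ccc(S(=O)(=O)c2ccccc2)cc1)c1cc2ncccc2s1`: 400 nM
compound 2 `O=C(NCc1ccc(S(=O)(=O)c2ccccc2)cc1)c1c[nH]c2ccncc12`: 1900 nM
compound 3 `O=C(NCc1ccc(S(=O)(=O)c2ccccc2)cc1)c1ccc2nncn2c1`: 370 nM

All three share the same amide and sulfone-bearing portion and differ only in the bicyclic group on the carbonyl carbon. In an assay for inhibition of Nicotinamide phosphoribosyltransferase (Homo sapiens), read by mass spectrometry, with stated times of 15 min and 30 min (on this read-out lower numbers stand for stronger inhibition and higher numbers for weaker inhibition), compound 3 gives 370 nM. Against compound 1 the gap is a 1.1-fold lower number from compound 1 to compound 3 (0.03 log units; within the scatter), so these two cannot be ordered. Compound 2 sits apart: a 5.1-fold lower number from compound 2 to compound 3 (0.71 log units; beyond the scatter), and likewise a 4.8-fold higher number from compound 1 to compound 2 (0.68 log units; beyond the scatter).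

Compound 4 `O=C(NCc1ccc(S(=O)(=O)c2ccccc2)cc1)c1cnc2nccn2c1` has not been measured. Relative to compound 3 the change is a group of 9 heavy atoms (6 carbon, 3 nitrogen; one five-membered aromatic ring with 2 hetero atoms, one six-membered aromatic ring with 2 hetero atoms) in place of a group of 9 heavy atoms (6 carbon, 3 nitrogen; one five-membered aromatic ring with 3 hetero atoms, one six-membered aromatic ring with 1 hetero atom), on a carbonyl carbon. The earlier swaps on the same carbonyl carbon span from no change beyond the scatter (a 1.1-fold lower number from compound 1 to compound 3 (0.03 log units; within the scatter)) to a modest shift (a 5.1-fold lower number from compound 2 to compound 3 (0.71 log units; beyond the scatter)). Within the data shown here, compound 4 keeps the same atom count and acceptor count as compound 3, so the nearest precedent is the pair of compound 1 and compound 3, where different bicycles of equal size gave no separation. A small step is therefore expected for compound 4, direction uncertain; a modest loss is not excluded given the spread seen with compound 2. The expected step is a 1.5-fold higher number from compound 3 to compound 4 (0.17 log units; within the scatter). For compound 4 in this assay the estimate is 550 nM, with a range of 200 nM to 1500 nM.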

Compound 4, half-maximal inhibitory concentration: 2 nM
Compound 4: middle estimate off by 280-fold (2.44 log units), on the high side; measured number below the stated range.
By their numbers in this assay, from the lowest: compound 4; then compounds 3 and 1 (each within the scatter of the next); then compound 2.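

In this assay, the group on the carbonyl carbon proves far more sensitive than compounds 1 to 3 suggested: with the same atoms joined differently and the same donor and acceptor counts, a 190-fold lower number from compound 3 to compound 4 (2.27 log units; beyond the scatter) is a large step. Equal heavy-atom count and composition therefore do not fix the number at this position, as the same composition in compound 3 and compound 4 gives widely separated values, whereas the earlier match between compound 1 and compound 3 gave no such hint. The group in compound 4 also stands clear of both other bicycles, with a 200-fold lower number from compound 1 to compound 4 (2.30 log units; beyond the scatter) and a 950-fold lower number from compound 2 to compound 4 (2.98 log units; beyond the scatter), making compound 4 the most potent of the four; no measurement shown bears on what lies behind this gain.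

From the compounds shown here alone, whether the gain survives a methyl group or a chlorine atom on the new bicycle remains open, and so does the effect of an amine or a carboxylic acid there. The compounds also leave open whether the same ranking of bicycles holds once the shared sulfone-bearing portion is changed.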